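The source may report more compounds than this note shows. Statements on the series, on what has been measured and on what is new or still open speak of the compounds shown alone.

Measured so far in a functional assay on KB cells (Homo sapiens) for cytotoxicity; a higher number here means that more compound is needed for the effect, a lower number that less compound is needed:
compound 1 `COC1=C(C)C(=O)/C(=C(O)/C=C/c2ccc(Br)cc2)C(=O)C1(C)C`, 1.7 ug/mL
compound 2 `COC1=C(C)C(=O)/C(=C(O)/C=C/c2cccc(OC)c2)C(=O)C1(C)C`, 3.3 ug/mL
compound 3 `COC1=C(C)C(=O)/C(=C(O)/C=C/c2ccccc2OC)C(=O)C1(C)C`, 3.3 ug/mL

Compound 3 stands level with compound 2 at the digits shown, the two together giving the highest numbers of the three. Its nearest neighbour is compound 2, with no change at the digits printed from compound 2 to compound 3 (within the scatter), and its furthest is compound 1, with a 1.9-fold higher number from compound 1 to compound 3 (0.29 log units; within the scatter), both within the scatter. Compound 4 `COC1=C(C)C(=O)/C(=C(O)/C=C/c2ccc(C)cc2)C(=O)C1(C)C` is not yet measured. The change from compound 3 to compound 4 is 4-methylphenyl in place of 2-methoxyphenyl on a double-bonded chain carbon bound to a double-bonded chain carbon. Among the compounds with values here, no measured step introduces 4-methylphenyl, so none bears on it directly. The steps that exchange the aryl group at the same place, a 1.9-fold higher number from compound 1 to compound 2 (0.29 log units; within the scatter), a 1.9-fold higher number from compound 1 to compound 3 (0.29 log units; within the scatter) and no change at the digits printed from compound 2 to compound 3 (within the scatter), all stay within the scatter. In this assay a step beyond the scatter is therefore not expected for compound 4. The expected step is a 1.3-fold lower number from compound 3 to compound 4 (0.12 log units; within the scatter). Compound 4 is estimated to give about 2.5 ug/mL, within 1.2 ug/mL to 5 ug/mL.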

Compound 4, concentration for half-maximal effect: 3.9 ug/mL
Compound 4: middle estimate off by 1.6-fold (0.19 log units), on the low side; low and high end bracket the measured number.
By their numbers in this assay, from the lowest: compounds 1, 2, 3 and 4 (each within the scatter of the next, the first and the last beyond it).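

In this assay, 4-methylphenyl in place of either methoxyphenyl on a double-bonded chain carbon bound to a double-bonded chain carbon gives a 1.2-fold higher number from compound 3 to compound 4 (0.07 log units; within the scatter) and a 1.2-fold higher number from compound 2 to compound 4 (0.07 log units; within the scatter) so these aryl groups remain unseparated here. Within the data shown here, the first step beyond the scatter at this place is methyl in place of bromo on an aromatic carbon, with a 2.3-fold higher number from compound 1 to compound 4 (0.36 log units; beyond the scatter) and a modest size, while compound 1 stays within the scatter of both methoxyphenyl compounds. No available evidence accounts for this difference.

Still open, on these data alone, is whether an amine or a carboxylic acid on the phenyl ring would move the number beyond the scatter, and whether a longer chain in place of methyl on the aromatic carbon would read as methyl does. As far as these compounds go, the shared core stays constant across these compounds, so its own contribution remains untested.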